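Ethoxy Replaced by Methyl: An Expectation for Compound 3

The compounds below may be only part of what the source reports. "The series", "measured", "known", "first", "only" and "open" are said of these compounds alone.

Two compounds built on the same core have so far been examined in a functional assay on HT-29 cells (Homo sapiens) for inhibition, read by flow cytometry, tested at 10 uM; a lower number here means less inhibition, a higher number more inhibition at the concentration tested (going by the name of the read-out). Compound 1 `O=C(CSc1nc2ccccc2[nH]1)c1ccc(O)cc1` is recorded as "not active" (no number reported) in this assay, with no number attached to that outcome. Compound 2 `CCOc1ccc(C(=O)CSc2nc3ccccc3[nH]2)cc1` gives 55.2% in this assay, and since this is the only numeric result available, compound 2 stands alone as the reference point for the series. Compound 3 `Cc1ccc(C(=O)CSc2nc3ccccc3[nH]2)cc1` has not yet been measured. It differs from compound 2 in a single place: methyl in place of ethoxy on an aromatic carbon. Going by the values given here, no pair of measured compounds separated by one change exists here, so the size of such a step cannot be read from the data. The account nevertheless expects a moderate drop in inhibition, beyond the usual scatter, estimated as a number 20.2 percentage points lower from compound 2 to compound 3 (beyond the scatter). Compound 3 is accordingly estimated to show 35% in this assay, with a range from 10% to 60%.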

Compound 3, a percentage reported as inhibition, at one concentration (the size of the read-out at that concentration, not a potency): 40%
Compound 3: the middle estimate sits 5 percentage points below what was measured; the measured number falls inside the stated range.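

Methyl in place of ethoxy on an aromatic carbon, para to a large group, gives in this assay a number 15.2 percentage points lower from compound 2 to compound 3 (beyond the scatter), the only step at this position that can be read. The oxygen of ethoxy is thus not needed for a numeric result in this assay: compound 3, whose methyl brings no hydrogen-bond acceptor, still gives 40%, whereas compound 1 is recorded as "not active" (no number reported). Nothing available accounts for the size of this step.

One step cannot separate the loss of the oxygen from the loss of heavy atoms at this position. Methoxy, which keeps the oxygen on a shorter chain, and propyl, which keeps the chain without the oxygen, are among the groups that would bear on this, while an amine in the same place remains an open case.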